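Extending a chain on a cyclohexyl-bearing core

The source may report more compounds than this note shows. Statements on the series, on what has been measured and on what is new or still open speak of the compounds shown alone.

Compound 1, `CCCCCCCCCCc1ccc(-c2c(C)[nH]c(=O)n2C)cc1`, is measured in a functional assay on brain (Rattus norvegicus, strain Wistar) for inhibition (on this read-out lower numbers stand for stronger inhibition and higher numbers for weaker inhibition), where compound 1 gives 7900 nM. Compound 2, `CCCCCCCCCCCCc1ccc(-c2c(C)[nH]c(=O)n2C)cc1`, is the same molecule carrying (ethyl in place of hydrogen on a saturated chain carbon, ten or more bonds along the chain from an aromatic carbon); in this assay compound 2 gives 13000 nM, and the step of a 1.6-fold higher number from compound 1 to compound 2 (0.22 log units; within the scatter).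

Compound 3, `CCCCCCCCc1ccc(-c2c(C)[nH]c(=O)n2C2CCCCC2)cc1`, has a different core; the difference between the two cores is not broken down here. In this assay compound 3 gives 10300 nM, which sits within the scatter of both compound 1 and compound 2.

Compound 4, `CCCCCCCCCCc1ccc(-c2c(C)[nH]c(=O)n2C2CCCCC2)cc1`, is not yet measured. It differs from compound 3 by ethyl in place of hydrogen on a saturated chain carbon, eight bonds along the chain from an aromatic carbon. Among the compounds with values here, this is the same kind of change as the one from compound 1 to compound 2, though it sits at a different place along the chain, as the two descriptions of the change show.

Because the step of a 1.6-fold higher number from compound 1 to compound 2 (0.22 log units; within the scatter) stayed within the scatter, the step from compound 3 to compound 4 is expected to be a 1.4-fold higher number from compound 3 to compound 4 (0.13 log units; within the scatter). Compound 4 is therefore estimated at 14000 nM, with a range from 6500 nM to 30000 nM.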

Compound 4, half-maximal inhibitory concentration: 27000 nM
For compound 4 the middle estimate is 1.9-fold (0.29 log units) below the measured one; the range from low to high includes it.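

In this assay, ethyl in place of hydrogen on a saturated chain carbon, eight bonds along the chain from an aromatic carbon, gives a 2.6-fold higher number from compound 3 to compound 4 (0.42 log units; beyond the scatter). Set beside the same kind of change on the core of compound 1, this step cannot be told apart from the earlier one: the same change on two cores in this assay, a 1.6-fold higher number (0.22 log units; within the scatter) from compound 1 to compound 2 and a 2.6-fold higher number (0.42 log units; beyond the scatter) from compound 3 to compound 4, 1.6-fold (0.20 log units) apart, within the scatter of two such steps. The two cores therefore fit a single shared effect of this change, but two pairs do not prove that the effect is the same on both, and they do not give its true size; the other new step, cyclohexyl in place of methyl on an aromatic nitrogen, gives a 3.4-fold higher number from compound 1 to compound 4 (0.53 log units; beyond the scatter), which is a separate comparison of the two groups at that nitrogen.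

The compounds shown leave open how a much shorter chain, or a chain carrying an amine or a carboxylic acid, would behave in this assay. They also leave open whether a phenyl group on that nitrogen would read like methyl or like cyclohexyl.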